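A Step from Compound 3 to Compound 4

A few compounds are considered here, and "the series" means these few. Any claim that something is new, unique, unknown or untested is made for them only; others in the source may bear on it.

Of the compounds shown here, three have been measured in an assay with Cystic fibrosis transmembrane conductance regulator (Rattus norvegicus) as the target; on this read-out higher numbers stand for weaker binding and lower numbers for tighter binding. Compound 1 `OCCc1cc(-c2ccccc2OCc2ccc(Br)cc2)no1` gives 23000 nM, compound 2 `COC(=O)C1CC(c2ccccc2OCc2ccc(Br)cc2)=NO1` gives 73000 nM, and compound 3 `COc1cccc(COc2ccccc2C2=NOC(CCl)C2)c1` gives 66000 nM. Among these three numbers compound 3 stands second highest; its nearest neighbour is compound 2, whose number lies within the scatter of that of compound 3, while compound 1 sits further off, with a lower number that lies beyond the scatter.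

Compound 4 `COc1cccc(COc2ccccc2-c2cc(CO)on2)c1` has not yet been measured in this assay. It differs from compound 3 in one place: a group of 7 heavy atoms (4 carbon, 1 nitrogen, 2 oxygen; one five-membered aromatic ring with 2 hetero atoms) in place of a group of 7 heavy atoms (4 carbon, 1 nitrogen, 1 oxygen, 1 chlorine; one five-membered non-aromatic ring with 2 hetero atoms), on an aromatic carbon. Within the data shown here, no pair of measured compounds differs by this change alone, so no measured step can be carried over. What the numbers do show is that compound 1, which carries a five-membered aromatic ring with 2 hetero atoms, lies beyond the scatter below compound 3, whereas compound 2, which like compound 3 carries a non-aromatic one, sits within the scatter of compound 3; compound 1 differs from both in other places as well, so this is only a hint. On that hint a step down in the number is expected from compound 3 to compound 4, a 1.9-fold lower number from compound 3 to compound 4 (0.28 log units; within the scatter), of a size near the edge of the scatter. Compound 4 is therefore estimated at 35000 nM, with a range from 12000 nM to 95000 nM.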

Compound 4, dissociation constant: 72000 nM
For compound 4 the middle estimate is 2.1-fold (0.31 log units) below the measured one; the measured number falls inside the stated range.
By their numbers in this assay, from the lowest: compound 1; then compounds 3, 4 and 2 (each within the scatter of the next).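

In this assay, replacing the non-aromatic ring of compound 3, on an aromatic carbon ortho to a large group, with the 5-(hydroxymethyl)-1,2-oxazol-3-yl group of compound 4 gives a 1.1-fold higher number from compound 3 to compound 4 (0.04 log units; within the scatter) and so does not separate the two groups on this read-out. At this position, then, a five-membered aromatic ring can stand in for the non-aromatic one, and a chlorine-bearing group can give way to one with a hydrogen-bond donor, without a step beyond the scatter. No data shown bear on why the number stays where it does.

From the compounds shown here alone, the step changes the ring and its side group at once, so the share of each stays open, as does whether an amine or a carboxylic acid in place of the hydroxyl of the 5-(hydroxymethyl)-1,2-oxazol-3-yl group would move the number. Also open, going by these compounds, is what sets compound 1 apart, as it differs from compound 3 and from compound 4 in more than one place.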